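Restoring a phenyl group on the urea-type nitrogen

A few compounds are considered here, and "the series" means these few. Any claim that something is new, unique, unknown or untested is made for them only; others in the source may bear on it.

In a functional assay on MGC-803 cells (Homo sapiens) for antiproliferative activity, read by MTT assay, with a stated time of 48 h (a higher number here means a weaker inhibitor, a lower number a stronger inhibitor), compound 2 (`O=C(Nc1cccc(CNc2nccnc2Cl)c1)NC1CCCCC1`) gives > 40000 nM, which is a limit of the assay and not a number. Compound 1 (`Cc1ccccc1NC(=O)Nc1cccc(CNc2nccnc2Cl)c1`) gives 14000 nM in this assay. Within the data shown here, one measured step bears on what follows: an at least 2.8-fold higher number from compound 1 to compound 2 (0.45 log units; beyond the scatter), with cyclohexyl in place of 2-methylphenyl on an amide-type nitrogen. Compound 3 (`O=C(Nc1cccc(CNc2nccnc2Cl)c1)Nc1ccc(Cl)cc1Br`) makes a change at that same place, with 2-bromo-4-chlorophenyl in place of cyclohexyl on an amide-type nitrogen. A substituted phenyl group thus returns there, as in compound 1 at 14000 nM, so a move to a lower number of at least modest size is expected. Among the measured compounds shown here, no measured compound carries this 2-bromo-4-chlorophenyl group, so the range stays wide. The estimated change is an at least 3.6-fold lower number from compound 2 to compound 3 (0.56 log units; beyond the scatter). For compound 3 the estimated value is 11000 nM, with an expected range from 3500 nM to 35000 nM.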

Compound 3, half-maximal inhibitory concentration: 7480 nM
The estimate for compound 3 lay 1.5-fold (0.17 log units) above the measured number, within the range that was stated.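

In this assay, among these compounds, a substituted phenyl group on the amide-type nitrogen in place of cyclohexyl gives an at least 5.3-fold lower number from compound 2 to compound 3 (0.72 log units; beyond the scatter), so the 2-methylphenyl group of compound 1 is no longer the only aromatic group on record at this place that reads better than cyclohexyl. Compound 2 stands at a limit of the assay and not a number, so this step has a floor and no known full size: the limit of > 40000 nM in this assay, at which 1 of the 3 values shown sits. Between the two aryl groups the step is a 1.9-fold lower number from compound 1 to compound 3 (0.27 log units; within the scatter), so the 2-bromo-4-chlorophenyl and 2-methylphenyl groups cannot be told apart here.

Still open, as far as these compounds go, is whether the bromine or the chlorine of compound 3 contributes anything on its own, and how an unsubstituted phenyl or a benzyl group would read at this nitrogen. All three compounds also share one core, so they say nothing about changes elsewhere in the structure.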